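This account rests on a few compounds, and the source may have more. Where it says the series, first, only, none or still open, it means among the compounds named here.

Two compounds of the series share one core. Compound 1 `CN(C)c1ccc(C2CC(c3ccc(-n4cncn4)cc3)=NN2C(=O)CCCl)cc1` gives 3.7% in a functional assay on MDA-MB-231 cells (Homo sapiens) for inhibition, read by sulforhodamine B assay, tested at 10 uM; on this read-out higher numbers stand for more inhibition at the one concentration tested (going by the name of the read-out) and lower numbers for less inhibition. Compound 2 `CN(C)c1ccc(C2CC(c3ccc(-n4cncn4)cc3)=NN2C(=O)c2cc(Cl)cc(Cl)c2)cc1` gives 9.4% in this assay and sits at the top of the two numbers shown, though a number 5.7 percentage points higher from compound 1 to compound 2 (within the scatter) keeps it within the scatter of compound 1. Compound 3 `CN(C)c1ccc(C2CC(c3ccc(-n4cncn4)cc3)=NN2C(=O)c2ccc(C(F)(F)F)cc2)cc1` differs from compound 2 by 4-(trifluoromethyl)phenyl in place of 3,5-dichlorophenyl on a carbonyl carbon. Going by the values given here, no measured step exchanges one aryl group for another; the only step known, from a 2-chloroethyl to an aryl group, was within the scatter. For compound 3 the number in this assay is estimated at 8%, between 0% and 20%. The estimate means a number 1.4 percentage points lower from compound 2 to compound 3 (within the scatter), expected to stay within the scatter.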

Compound 3, a percentage reported as inhibition, at one concentration (the size of the read-out at that concentration, not a potency): 16.7%
Compound 3: the middle estimate sits 8.7 percentage points below what was measured, and the stated range covers the measured number.
By their numbers in this assay, from the lowest: compounds 1, 2 and 3 (each within the scatter of the next, the first and the last beyond it).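

In this assay the exchange of one aryl group for another on the carbonyl carbon gives a number 7.3 percentage points higher from compound 2 to compound 3 (within the scatter) and so does not separate these two aryl groups. Going by these compounds alone, replacing 2-chloroethyl with 4-(trifluoromethyl)phenyl gives a number 13 percentage points higher from compound 1 to compound 3 (beyond the scatter) as the only step at this position beyond the scatter, whereas compound 2, with 3,5-dichlorophenyl, stays within the scatter of compound 1, so an aryl group alone does not account for it. No available evidence bears on this difference.

On these data alone, whether a phenyl group carrying an amine or a carboxylic acid would change the number at this position remains open. So does the effect of a chain longer than 2-chloroethyl.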